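The source may report more compounds than this note shows. Statements on the series, on what has been measured and on what is new or still open speak of the compounds shown alone.

Working notes on the series in a functional assay on IMR-32 cells (Homo sapiens) for antiproliferative activity, with a stated time of 72 h; a lower number here means a stronger inhibitor, a higher number a weaker inhibitor: compound 1 `Cc1cc(C)cc(C(=O)N(CCC(=O)NCc2ccccc2)Cc2ccc(C(=O)NO)cc2)c1` gives 1390 nM and compound 2 `CN(C)c1ccc(C(=O)N(CCC(=O)NCc2ccccc2)Cc2ccc(C(=O)NO)cc2)cc1` gives 840 nM. Among the compounds with values here, the only measured step, a 1.7-fold lower number from compound 1 to compound 2 (0.22 log units; within the scatter), also replaced the group on a carbonyl carbon, so compound 2 stands level with compound 1. Compound 3 `Cc1ccc(C(=O)N(CCC(=O)NCc2ccccc2)Cc2ccc(C(=O)NO)cc2)cc1` differs from compound 2 by methyl in place of dimethylamino on an aromatic carbon, with methyl in place of dimethylamino on an aromatic carbon. From the compounds shown here alone, with that single step as the guide, no change beyond the scatter is expected in this assay, and the direction stays open. The expected step is a 1.2-fold higher number from compound 2 to compound 3 (0.08 log units; within the scatter). Compound 3 is estimated at 1000 nM, within a range of 450 nM to 2200 nM.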

Compound 3, half-maximal inhibitory concentration: 630 nM
The estimate for compound 3 lay 1.6-fold (0.20 log units) above the measured number, within the range that was stated.
By their numbers in this assay, from the lowest: compounds 3, 2 and 1 (each within the scatter of the next, the first and the last beyond it).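

In this assay the step of a 1.3-fold lower number from compound 2 to compound 3 (0.12 log units; within the scatter) leaves methyl and dimethylamino level at this aromatic carbon, para to a large group. Within the data shown here, the step of a 2.2-fold lower number from compound 1 to compound 3 (0.34 log units; beyond the scatter) is the first beyond the scatter, though modest, and it comes with 4-methylphenyl in place of 3,5-dimethylphenyl on the carbonyl carbon. Nothing measured here accounts for either step.

Open, from the compounds shown here alone, is whether methoxy, chlorine or a carboxylic acid at this place would stay level with methyl. Also open, going by these compounds, is how a longer chain there would read.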